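Swapping methylamino for isopropyl in a stability test

The source may hold more compounds than are shown below. What is called first, only, known or untested is meant among the compounds shown, and "the series" means these compounds.

In an ADME assay on microsomes from liver (Rattus norvegicus) for metabolic stability, with a stated time of 60 min, tested at 1 uM (on this read-out higher numbers stand for a more stable compound and lower numbers for a less stable compound), compound 1 `COc1cc(-c2cnn3cc(OC)c(-c4cnn(C)c4)nc23)ccn1` gives 56%, and compound 2 `CNc1nc2c(-c3ccnc(OC)c3)cnn2cc1OC` is the higher of the two at 74%. Compound 3 `COc1cc(-c2cnn3cc(OC)c(C(C)C)nc23)ccn1` changes the same place on the core: isopropyl in place of methylamino on an aromatic carbon. Among the compounds with values here, the one measured step there is a number 18 percentage points higher from compound 1 to compound 2 (beyond the scatter), with methylamino in place of 1-methyl-1H-pyrazol-4-yl. Isopropyl has not yet been measured at this place, so the range stays wide. Losing methylamino may undo that modest gain, so the expected change is a number 19 percentage points lower from compound 2 to compound 3 (beyond the scatter). For compound 3 the estimate is 55%, with an expected range of 33% to 74%.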

Compound 3, percent of the compound remaining: 14%
Estimate against measurement, compound 3: 41 percentage points above; the measured number lies below the stated range.
By their numbers in this assay, from the lowest: compound 3; then compound 1; then compound 2.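

In this assay this position proves far more sensitive than the first pair showed, with a number 60 percentage points lower from compound 2 to compound 3 (beyond the scatter) and with a number 42 percentage points lower from compound 1 to compound 3 (beyond the scatter). Isopropyl, the only one of the three groups made of carbon alone, gives the lowest number of the set. Nothing available here explains the drop. On these data alone, whether an ethylamino group, a dimethylamino group or a longer carbon chain at this place would stay close to compound 2 or fall towards compound 3 remains open. So does whether the nitrogen or the branched shape decides the outcome.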